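A few compounds are considered here, and "the series" means these few. Any claim that something is new, unique, unknown or untested is made for them only; others in the source may bear on it.

Compound 1 `N#CC1CN1C(=O)Nc1ccc(F)cc1` is the starting point. Among the measured compounds shown here, in a functional assay on RPMI-8226 cells (Homo sapiens) for inhibition (on this read-out lower numbers stand for stronger inhibition and higher numbers for weaker inhibition), compound 1 gives 5000 nM, the lower of the two numbers measured so far. Compound 2 `N#CC1CN1C(N)=O`, a smaller compound, gives 288000 nM in this assay, a far higher number that lies well beyond the usual scatter. Compound 3 `N#CC1CN1C(=O)Nc1ccc(S(N)(=O)=O)cc1` differs from compound 1 by sulfamoyl in place of fluoro on an aromatic carbon. For the measured compounds named here, no measured pair shows what this exchange does, so the step from compound 1 to compound 3 in this assay is expected to be a 1.3-fold lower number from compound 1 to compound 3 (0.10 log units; within the scatter), that is, little or none beyond the scatter, with wide uncertainty. Compound 3 is therefore estimated to give about 4000 nM, somewhere between 700 nM and 25000 nM.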

Compound 3, half-maximal inhibitory concentration: > 38000 nM
Compound 3: a limit, no number (the forecaster's own chance of this, stated with the estimate: 10%); at least 9.5-fold (0.97 log units) between middle value and limit.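

For compound 3, this assay gives a limit of the assay and not a number: the limit of > 38000 nM in this assay, at which 1 of the 3 values shown sits. Even so, sulfamoyl in place of fluoro on this aromatic carbon brings an at least 7.6-fold higher number from compound 1 to compound 3 (0.88 log units; beyond the scatter), so the read-out responds to what sits at this position. Among the compounds shown here, the earlier compounds held no exchange at this place, so this is the first sign of that response. From the compounds shown here alone, how far the step extends remains unknown, as only its lower end is fixed. Also open, going by these compounds, is what a methyl, a chloro, an amine or a carboxylic acid would give on the same carbon.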